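The compounds below may be only part of what the source reports. "The series", "measured", "known", "first", "only" and "open" are said of these compounds alone.

Working notes on the series measured in a functional assay on HTB-54 cells (Homo sapiens) for cytotoxicity, read by MTT assay, with a stated time of 72 h; a higher number here means a weaker inhibitor of growth, a lower number a stronger inhibitor of growth. Compound 1 `COc1ccc(OC(=O)Nc2ccc([Se]C#N)cc2)cc1` gives 23700 nM in this assay. Compound 2 `N#C[Se]c1ccc(NC(=O)OCc2ccc([N+](=O)[O-])cc2)cc1` gives 22900 nM in this assay. The two numbers lie within the scatter of each other, so neither compound can be put ahead of the other; compound 1 stands among two values that cannot be told apart. Among the measured compounds shown here, no step between measured compounds that differ in a single place is available, so nothing is yet known here about how one substituent change shifts growth inhibition.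

Compound 3 `N#C[Se]c1ccc(NC(=O)Oc2ccc(Cl)cc2)cc1` is not yet measured. It differs from compound 1 in one place: chloro in place of methoxy on an aromatic carbon. For the measured compounds named here, with no comparable step to go on, the expectation rests only on the two measured compounds, which both sit near the same value. The expected step of a 1.2-fold lower number from compound 1 to compound 3 (0.07 log units; within the scatter) is small, most likely none beyond the scatter, in either direction. Compound 3 is estimated at 20000 nM in this assay, with a range from 8000 nM to 50000 nM.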

Compound 3, concentration for 50% growth inhibition: 13800 nM
The estimate for compound 3 lay 1.4-fold (0.16 log units) above the measured number; low and high end bracket the measured number.
By their numbers in this assay, from the lowest: compounds 3, 2 and 1 (each within the scatter of the next).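

Among the compounds shown here, the first step in a single place in this assay is chloro in place of methoxy on an aromatic carbon, para to a large group, and it reads a 1.7-fold lower number from compound 1 to compound 3 (0.23 log units; within the scatter). This position therefore accepts the exchange of methoxy for chloro with no shift that can be told from the scatter, so the step gives no sign yet that growth inhibition responds to the group held here. Nothing available bears on why the step has this size.

From the compounds shown here alone, whether an amine or a carboxylic acid at this position, or a longer alkoxy chain in place of methoxy, would move the number beyond the scatter remains open. Also open, going by these compounds, is whether chloro in place of the nitro group of compound 2 would give a step of similar size.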